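The source may hold more compounds than are shown below. What is called first, only, known or untested is meant among the compounds shown, and "the series" means these compounds.

Measured so far in an ADME assay on BV-2 cells (Mus musculus) for cytotoxicity, read by MTT assay, with a stated time of 48 h, tested at 100 uM; on this read-out lower numbers stand for a stronger effect and higher numbers for a weaker effect at the one concentration tested:

Compound 1, `O=C1COCCN1c1ccc(/N=C\c2c[nH]c3ccccc23)cc1`: 101%
Compound 2, `Cc1ccc(S(=O)(=O)n2cc(/C=N\c3ccc(N4CCOCC4=O)cc3)c3ccccc32)cc1`: 57.4%
Compound 3, `O=C1COCCN1c1ccc(/N=C\c2cn(C(=O)c3ccccc3)c3ccccc23)cc1`: 52.9%

Compound 3 has the lowest of the three numbers in this assay, but its gap to compound 2 is within the scatter, so the two cannot be ordered; only compound 1 stands clearly apart, with a number 48.1 percentage points lower from compound 1 to compound 3 (beyond the scatter) and a number 43.6 percentage points lower from compound 1 to compound 2 (beyond the scatter). The move from compound 2 to compound 3, a number 4.5 percentage points lower from compound 2 to compound 3 (within the scatter), shows that exchanging one group on the aromatic nitrogen for another left the read-out essentially where it was.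

Compound 4, `O=C1COCCN1c1ccc(/N=C\c2cn(C(=O)c3ccc(Cl)cc3)c3ccccc23)cc1`, differs from compound 3 by chloro in place of hydrogen on an aromatic carbon. Among the compounds with values here, none of the measured steps touches this part of the molecule; all three concern the group on the aromatic nitrogen. Within the data shown here, the only step that alters a group already present rather than adding one, the move from compound 2 to compound 3, stayed within the scatter. Compound 4 is therefore expected to give a step of a number 2.9 percentage points lower from compound 3 to compound 4 (within the scatter), not beyond the scatter. The estimated value of compound 4 in this assay is 50%, in the range 35% to 65%.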

Compound 4, a percentage reported as activity, at one concentration (the size of the read-out at that concentration, not a potency): 80.5%
Estimate against measurement, compound 4: 30.5 percentage points below; measured number outside the range, above it.
By their numbers in this assay, from the lowest: compounds 3 and 2 (each within the scatter of the next); then compound 4; then compound 1.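

In this assay the ring of the benzoyl group turns out to be a responsive place: chloro in place of hydrogen, para to a large group, gives a number 27.6 percentage points higher from compound 3 to compound 4 (beyond the scatter) (a change far from the aromatic nitrogen, where all earlier variation lay). It also separates two groups on that nitrogen that had seemed interchangeable, as (4-chlorophenyl)carbonyl in place of (4-methylphenyl)sulfonyl gives a number 23.1 percentage points higher from compound 2 to compound 4 (beyond the scatter) (whereas benzoyl stayed within the scatter of the sulfonyl group). The acyl group still counts, since the step from the unsubstituted nitrogen remains a number 20.5 percentage points lower from compound 1 to compound 4 (beyond the scatter) (modest now, where that of benzoyl was large).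

Nothing available accounts for this shift. As far as these compounds go, whether a methoxy group, an amine or a fluoro group in the same place would move the number the same way remains open.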